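This account rests on a few compounds, and the source may have more. Where it says the series, first, only, none or still open, it means among the compounds named here.

Compound 1 `c1ccc(-c2cc(-c3cccnc3)nc(-c3ccccn3)c2)cc1`: 0.28 ug/mL
Compound 2 `c1ccc(-c2cc(-c3cccs3)cc(-c3ccccn3)n2)nc1`: 0.0021 ug/mL
Compound 3 `c1ccc(-c2cc(-c3cccs3)cc(-c3ccncc3)n2)nc1`: 0.22 ug/mL

These values come from a functional assay on PC-3 cells (Homo sapiens) for antiproliferative activity; a higher number here means a weaker inhibitor of growth, a lower number a stronger inhibitor of growth. Compound 3, at 0.22 ug/mL, lies within the usual scatter of compound 1 and far from compound 2.

The next compound, compound 4 `c1ccc(-c2cc(-c3cccs3)cc(-c3cccnc3)n2)nc1`, has the same atoms as compound 3, joined differently: pyridin-3-yl in place of pyridin-4-yl on an aromatic carbon. Pyridin-3-yl takes the place of pyridin-4-yl on an aromatic carbon, next to the ring nitrogen.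

Among the measured compounds shown here, one measured step bears directly on this place: a 100-fold higher number from compound 2 to compound 3 (2.02 log units; beyond the scatter), a large step with pyridin-4-yl in place of pyridin-2-yl. It shows that swapping one pyridine for another here can matter greatly, but compound 4 has no pyridin-2-yl at this place. Compound 1 also carries pyridin-3-yl, with other differences from compound 4, and compound 1 gives 0.28 ug/mL.

No step beyond the scatter is therefore expected in this assay, though a surprise remains possible. The estimated step is a 1.1-fold lower number from compound 3 to compound 4 (0.04 log units; within the scatter). For compound 4 the expected value is 0.2 ug/mL, with an estimated range from 0.04 ug/mL to 0.8 ug/mL.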

Compound 4, concentration for 50% growth inhibition: 0.031 ug/mL
Compound 4: the middle estimate sits 6.5-fold (0.81 log units) above what was measured; the whole stated range lies above it.
By their numbers in this assay, from the lowest: compound 2; then compound 4; then compounds 3 and 1 (each within the scatter of the next).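

In this assay the three pyridine groups at this place now separate into three levels: pyridin-3-yl in place of pyridin-4-yl lowers the number (a 7.1-fold lower number from compound 3 to compound 4 (0.85 log units; beyond the scatter)), yet pyridin-2-yl still gives the lowest number (a 15-fold higher number from compound 2 to compound 4 (1.17 log units; beyond the scatter)). The attachment point of this ring therefore does more than divide one favoured group from two equal ones, and pyridin-3-yl occupies the middle level among these three compounds. A second place also matters, since thiophen-2-yl in place of phenyl lowers the number with pyridin-3-yl present (a 9.0-fold lower number from compound 1 to compound 4 (0.96 log units; beyond the scatter)).

The data shown offer no explanation for why the pyridine attachment point changes growth inhibition so strongly. Going by these compounds, it also remains open how a pyridine ring carrying an added amine or methoxy group would behave at this place.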